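The source may report more compounds than this note shows. Statements on the series, on what has been measured and on what is new or still open speak of the compounds shown alone.

Measured compounds:
Compound 1, `Cc1cnc(Nc2ccc(C#N)cc2)nc1Nc1c(F)cc(-c2ccsc2)cc1F`: in a toxicity assay on MT4 cells (Homo sapiens) for cytotoxicity, read by MTT assay, with a stated time of 5 days (a higher number here means that more compound is tolerated, a lower number that less compound is tolerated), compound 1 gives 261000 nM.
Compound 2, `Cc1cc(-c2cccs2)cc(C)c1Nc1ccnc(Nc2ccc(C#N)cc2)n1`: in this assay compound 2 gives 10000 nM.

Compound 2 stands at the lowest of the two numbers; compound 1 lies on the higher side by a gap beyond the scatter, so of the two, compound 2 is the less tolerated. The two measured compounds differ in several places, so their gap gives no guide to any single change.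

Compound 3, `Cc1cc(-c2cc(F)nc(F)c2)cc(C)c1Nc1ccnc(Nc2ccc(C#N)cc2)n1`, is not yet measured. It differs from compound 2 in one place: 2,6-difluoropyridin-4-yl in place of thiophen-2-yl on an aromatic carbon. For the measured compounds named here, no pair of measured compounds shows this change, so no measured step anchors the expectation. The expected step is a 2.0-fold higher number from compound 2 to compound 3 (0.30 log units; within the scatter), a modest move toward a higher number, possibly not beyond the scatter. For compound 3 the estimated value in this assay is 20000 nM, with a range from 6000 nM to 70000 nM.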

Compound 3, half-maximal cytotoxic concentration: 6300 nM
The estimate for compound 3 lay 3.2-fold (0.50 log units) above the measured number; the range from low to high includes it.
By their numbers in this assay, from the lowest: compounds 3 and 2 (each within the scatter of the next); then compound 1.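

Notes on the position meta to two methyl groups and para to a large group: in this assay, 2,6-difluoropyridin-4-yl in place of thiophen-2-yl gives a 1.6-fold lower number from compound 2 to compound 3 (0.20 log units; within the scatter), so the two compounds cannot be told apart. For the compounds shown here, this is the first one-place comparison at this position, and it shows that exchanging a five-membered aromatic ring of 5 heavy atoms for a six-membered aromatic ring of 8 heavy atoms leaves the number within the scatter. No measurement at hand bears on the reason for this result.

Still open, from the compounds shown here alone, is whether any group at this position can move the number beyond the scatter. An amine, a carboxylic acid or a longer alkyl chain there would test this, as these differ from both aromatic rings.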